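Removing one ring methyl from compound 2

The source may hold more compounds than are shown below. What is called first, only, known or untested is meant among the compounds shown, and "the series" means these compounds.

In a functional assay for inhibition, with Rattus norvegicus as the target (a higher number here means a weaker inhibitor, a lower number a stronger inhibitor), compound 1 `CCC(C)(C)/N=c1\c(O)c(O)\c1=N/Cc1c(C)cc(C)cc1Cl` gives 200 nM. In this assay compound 2 `CCC(C)(C)/N=c1\c(O)c(O)\c1=N/Cc1c(C)cc(C)cc1C` gives 310 nM; the step of a 1.6-fold higher number from compound 1 to compound 2 (0.19 log units; within the scatter) leaves the two values within the scatter of each other, so compound 2 is not set apart from compound 1 on these numbers. Compound 3 `CCC(C)(C)/N=c1\c(O)c(O)\c1=N/Cc1c(C)cccc1C` differs from compound 2 by hydrogen in place of methyl on an aromatic carbon. Going by the values given here, no measured step removes a methyl; the single step known exchanges one group for another and stays within the scatter. The expected step is therefore small, a 1.3-fold higher number from compound 2 to compound 3 (0.11 log units; within the scatter), leaning if anything toward a higher number. Compound 3 is estimated at 400 nM, in the range 150 nM to 1100 nM.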

Compound 3, half-maximal inhibitory concentration: 830 nM
Compound 3: middle estimate off by 2.1-fold (0.32 log units), on the low side, within the range that was stated.
By their numbers in this assay, from the lowest: compounds 1 and 2 (each within the scatter of the next); then compound 3.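

Going by these compounds alone, the step in this assay, a 2.7-fold higher number from compound 2 to compound 3 (0.43 log units; beyond the scatter), is the first to lie beyond the scatter, although it is modest. This ring carbon, para to a large group, therefore responds to the loss of its methyl, with hydrogen there giving the higher number. No available measurement accounts for this step.

Still open, as far as these compounds go, is whether chloro, ethyl or methoxy at this carbon would match methyl or give a lower number. From the compounds shown here alone, it is also open whether the same step would hold with chloro on the ring, as in compound 1.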